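This account rests on a few compounds, and the source may have more. Where it says the series, first, only, none or still open, it means among the compounds named here.

Measured so far:
compound 1 `CCCCCCCNC(=N)NC(=N)Nc1ccc(F)c(F)c1`: 2100 nM
compound 2 `CCN(CC)C(=N)NC(=N)Nc1ccc(F)c(F)c1`: 22100 nM
compound 3 `CC(C)NC(=N)NC(=N)Nc1ccc(F)c(F)c1`: 25000 nM

In a functional assay on UMUC3 cells (Homo sapiens) for antiproliferative activity, read by MTT assay, with a stated time of 72 h (a higher number here means a weaker inhibitor, a lower number a stronger inhibitor), compound 3 gives 25000 nM, the highest of the three numbers. Compound 2 sits closest to it, and the two lie within the scatter of each other, as a 1.1-fold higher number from compound 2 to compound 3 (0.05 log units; within the scatter) shows. Compound 1 is far off: a 12-fold higher number from compound 1 to compound 3 (1.08 log units; beyond the scatter), a large step that comes from swapping the chain on the amine nitrogen.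

Compound 4 `CC(C)NC(=N)NC(=N)Nc1ccc(F)cc1` keeps the isopropyl group and the rest of the core of compound 3 and changes only the ring: hydrogen in place of fluoro on an aromatic carbon. Among the compounds with values here, both measured steps concern the amine side of the molecule, not the ring that bears the fluoro groups, so no measured step speaks directly to this change. Within the data shown here, the only thing the numbers say is that the ring has been held constant throughout, so its contribution cannot be read from these data.

With nothing pointing either way, the expected step in this assay is no change at the digits printed from compound 3 to compound 4 (within the scatter), that is, none beyond the scatter. Compound 4 is therefore estimated at 25000 nM, with a range from 8000 nM to 70000 nM, and given how high compound 3 already sits, there is a real chance that only a limit is reported.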

Compound 4, half-maximal inhibitory concentration: > 50000 nM
Compound 4 ended at the assay's limit; the forecaster's own chance of this, stated with the estimate: 20%; middle value at least 2.0-fold (0.30 log units) away from the limit.
By their numbers in this assay, from the lowest: compound 1; then compounds 2 and 3 (each within the scatter of the next). At a limit, above all of these: compound 4.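

In this assay compound 4 gives > 50000 nM as a limit of the assay and not a number: the limit of > 50000 nM in this assay, at which 1 of the 4 values shown sits. Replacing the fluoro group on the aromatic carbon ortho to the remaining fluoro group and meta to a large group gives an at least 2.0-fold higher number from compound 3 to compound 4 (0.30 log units; that floor lies within the scatter), so only a floor is known for this change, and that floor alone does not separate the two compounds. Within the data shown here, this is still the first information on the ring, as every earlier step concerned the amine side: here, hydrogen brings no lower number, and the true size of the change may be anywhere from that floor upward.

The compounds shown leave open whether chlorine, a methyl group or a methoxy group on this aromatic carbon would keep, lower or raise the number compared with fluoro. They also leave open whether a heptyl chain on the amine nitrogen, the feature of compound 1, would bring a measurable number back to the ring with a single fluoro group.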